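Fluoro added to the bromophenyl arm of compound 2

A few compounds are considered here, and "the series" means these few. Any claim that something is new, unique, unknown or untested is made for them only; others in the source may bear on it.

Measured so far in a functional assay on HL-60 cells (Homo sapiens) for cytotoxicity, read by CCK-8 assay, with a stated time of 72 h; on this read-out higher numbers stand for weaker inhibition and lower numbers for stronger inhibition:
- compound 1 `COc1ccccc1/C=c1\c(=O)[nH]/c(=C/c2cccc(Cl)c2Cl)c(=O)n1C`: 200 nM
- compound 2 `C=CCn1c(=O)/c(=C\c2cccc(Br)c2)[nH]c(=O)/c1=C\c1ccccc1OC`: 5200 nM
- compound 3 `C=CCn1c(=O)/c(=C\c2cccc(Br)c2)[nH]c(=O)/c1=C\c1cccc(Br)c1`: "not active" (no number reported), with no number reported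

Compound 2 has the highest number of the two reported; compound 1 gives 200 nM, a gap beyond the scatter. Compound 3 gave no number at all in this assay.

Compound 4 `C=CCn1c(=O)/c(=C\c2cc(Br)ccc2F)[nH]c(=O)/c1=C\c1ccccc1OC` differs from compound 2 in one place: fluoro in place of hydrogen on an aromatic carbon. Put another way, the 3-bromophenyl arm becomes 5-bromo-2-fluorophenyl, the fluoro standing ortho to the large group and para to the bromo group.

For the measured compounds named here, no measured pair shows this change, so nothing fixes its size. For compound 4 the step of a 1.3-fold lower number from compound 2 to compound 4 (0.11 log units; within the scatter) is expected to stay within the scatter, in either direction. Compound 4 is thus estimated at 4000 nM, with a range of 1500 nM to 12000 nM in this assay.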

Compound 4, half-maximal inhibitory concentration: 17400 nM
The estimate for compound 4 lay 4.4-fold (0.64 log units) below the measured number; measured number above the stated range.
By their numbers in this assay, from the lowest: compound 1; then compound 2; then compound 4.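

Fluoro on this aromatic carbon costs activity in this assay with a 3.3-fold higher number from compound 2 to compound 4 (0.52 log units; beyond the scatter) as the first single-place step in the series. The 3-bromophenyl arm of compound 2 is therefore sensitive to even a single added fluorine atom at this position, and the step is modest but real. No available data account for this loss.

Still open, going by these compounds, is whether an amine or a carboxylic acid at the same aromatic carbon would weaken activity as well. Also open, on these data alone, is whether fluoro has the same effect on the methoxyphenyl arm.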